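This account rests on a few compounds, and the source may have more. Where it says the series, first, only, none or still open, it means among the compounds named here.

Within the data shown here, in a physicochemical assay for solubility, in simulated intestinal fluid, with a stated time of 4 h (a higher number here means a more soluble compound, a lower number a less soluble compound), compound 2 `N#Cc1ccc(O[C@H]2CN(S(=O)(=O)c3ccc(C(F)(F)F)cc3C#N)C[C@@]2(O)CO)cc1F` gives 25 ug/mL, the higher of the two numbers measured so far. Compound 1 `N#Cc1ccc(O[C@H]2CN(S(=O)(=O)c3ccc(C(F)(F)F)cc3)C[C@@]2(O)CO)cc1F` gives 5 ug/mL. These two compounds differ in one place, an added cyano group, and the measured step is a 5.0-fold higher number from compound 1 to compound 2 (0.70 log units; beyond the scatter). Compound 3 `N#Cc1ccc(O[C@H]2CN(S(=O)(=O)c3ccccc3C#N)C[C@@]2(O)CO)cc1F` keeps that cyano group and changes another place, with hydrogen in place of trifluoromethyl on an aromatic carbon. Among the measured compounds shown here, no measured step covers this change, so the step to compound 2 is only a rough guide to size, and the direction is a judgement with real uncertainty. A modest rise, somewhat smaller than that step, seems most likely. The expected step is a 2.0-fold higher number from compound 2 to compound 3 (0.30 log units; within the scatter). The estimate for compound 3 is 50 ug/mL, with an expected range of 20 ug/mL to 120 ug/mL.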

Compound 3, solubility: 20 ug/mL
For compound 3 the middle estimate is 2.5-fold (0.40 log units) above the measured one; measured number inside the range.
By their numbers in this assay, from the lowest: compound 1; then compounds 3 and 2 (each within the scatter of the next).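

In this assay, putting hydrogen in place of trifluoromethyl, on the aromatic carbon meta to a cyano group, gives a 1.3-fold lower number from compound 2 to compound 3 (0.10 log units; within the scatter), so with the cyano group present this assay does not tell the two groups apart at this place. The wider comparison gives a 4.0-fold higher number from compound 1 to compound 3 (0.60 log units; beyond the scatter); this step spans two places, the added cyano group and the loss of trifluoromethyl, and it shows that the higher number does not depend on keeping trifluoromethyl. Nothing available here accounts for either step.

The compounds shown leave open how trifluoromethyl and hydrogen compare at this carbon without the cyano group, and how a compound with hydrogen at both places would read. They also leave open whether an amine or a carboxylic acid at this carbon would move the number beyond the scatter.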